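One added methyl on the shared core

The source may report more compounds than this note shows. Statements on the series, on what has been measured and on what is new or still open speak of the compounds shown alone.

- Compound 1 `O=C(CCCCCCN1C(=O)/C(=N\O)c2ccccc21)NO` gives 890 nM 
- Compound 2 `CO/N=C1/C(=O)N(CCCCCCC(=O)NO)c2ccccc21` gives 750 nM 

Both compounds were tested in a functional assay on NCI-H460 cells (Homo sapiens) for antiproliferative activity, read by sulforhodamine B assay, with a stated time of 48 h (on this read-out lower numbers stand for stronger inhibition and higher numbers for weaker inhibition), and their numbers lie within the usual scatter of each other. On this evidence, compound 2 stands level with compound 1, and the two cannot be ranked.

Compound 3 `CO/N=C1/C(=O)N(CCCCCCC(=O)NO)c2ccc(C)cc21` has not yet been measured. It differs from compound 2 in a single place: the change methyl in place of hydrogen on an aromatic carbon puts methyl in place of hydrogen on an aromatic carbon. Among the measured compounds shown here, no measured pair differing in one place is available, so the data offer no direct guide to the effect of this change. The expectation therefore starts from compound 2 at 750 nM and assumes no shift beyond the scatter in this assay in either direction, though a real move cannot be excluded. The estimate amounts to an expected 1.3-fold lower number from compound 2 to compound 3 (0.10 log units; within the scatter) and no more than that. Compound 3 is expected near 600 nM with an estimated span from 200 nM to 1800 nM as the likely range.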

Compound 3, half-maximal inhibitory concentration: 1190 nM
Beside the measured number, compound 3's estimate is 2.0-fold (0.30 log units) below it; low and high end bracket the measured number.
By their numbers in this assay, from the lowest: compounds 2, 1 and 3 (each within the scatter of the next).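

In this assay, among the compounds shown here, the swap of hydrogen for methyl on this aromatic carbon gives a 1.6-fold higher number from compound 2 to compound 3 (0.20 log units; within the scatter) and is the first step that differs in one place only. It shows that the shared core can carry a methyl at this carbon of the six-membered aromatic ring, meta to a fused ring and para to a fused ring, with the antiproliferative read-out staying within the usual scatter, so this single step gives no sign that the position matters for the read-out in either direction. Nothing is available beyond the numbers themselves to account for the result, and the step therefore stands without an explanation. For the compounds shown here, what remains open is whether a chlorine atom, a methoxy group, an amine or a carboxylic acid on this same carbon would also stay within the scatter, since a methyl is the only group seen here. Also open, going by these compounds, is whether a methyl on the other aromatic carbons of the shared core would read the same way, or whether a phenyl ring at this position would move the number beyond the scatter.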